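This account rests on a few compounds, and the source may have more. Where it says the series, first, only, none or still open, it means among the compounds named here.

Measured so far in a functional assay for inhibition, tested at 100 ug/mL; on this read-out lower numbers stand for a weaker effect and higher numbers for a stronger effect at the one concentration tested:
compound 1 `Cc1cc(O)c(C(C)C)cc1-c1cc(-c2ccccc2)c(C#N)c(=O)[nH]1`: 41%
compound 2 `Cc1cc(O)c(C(C)C)cc1-c1cc(-c2ccco2)c(C#N)c(=O)[nH]1`: 70%

Compound 2 holds the higher of the two numbers; its nearest neighbour is compound 1, lower by a step beyond the scatter. Among the compounds with values here, the one measured step, a number 29 percentage points higher from compound 1 to compound 2 (beyond the scatter), exchanged the group on the same aromatic carbon that is now varied again. Compound 3 `Cc1cc(O)c(C(C)C)cc1-c1cc(-c2ccccc2[N+](=O)[O-])c(C#N)c(=O)[nH]1` is compound 2 with 2-nitrophenyl in place of furan-2-yl on an aromatic carbon. Within the data shown here, that single step is the only guide: it shows that swapping the group at this carbon can move this assay by a modest amount, and the group entering in compound 3 is a six-membered aromatic ring of carbon only, as in compound 1, rather than the five-membered ring with one hetero atom of compound 2. Among the measured compounds shown here, a 2-nitrophenyl has no measured precedent, so the range is kept wide. On this basis a move back toward compound 1 is expected rather than a further gain. The step expected from this change is a number 20 percentage points lower from compound 2 to compound 3 (beyond the scatter). For compound 3 the estimate is 50%, expected to fall within 30% to 72%.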

Compound 3, a percentage reported as inhibition, at one concentration (the size of the read-out at that concentration, not a potency): 37.5%
Compound 3: middle estimate off by 12.5 percentage points, on the high side; measured number inside the range.
By their numbers in this assay, from the lowest: compounds 3 and 1 (each within the scatter of the next); then compound 2.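

In this assay the step is a number 32.5 percentage points lower from compound 2 to compound 3 (beyond the scatter), so the higher number seen with furan-2-yl does not carry over to 2-nitrophenyl at this carbon on the pyridone-free reading of the shared core. Nitro in place of hydrogen on the phenyl group gives a number 3.5 percentage points lower from compound 1 to compound 3 (within the scatter), so this added group leaves the two compounds with a six-membered aromatic ring of carbon only indistinguishable at the one concentration tested, and among these three compounds only compound 2, with its five-membered ring, stands apart. No supporting data bear on why the read-out behaves this way.

On these data alone, whether the higher number belongs to furan-2-yl alone or extends to other five-membered aromatic rings, such as thiophen-2-yl, remains open. Also open, as far as these compounds go, is whether an amine or a methoxy group on the phenyl group would read any differently from nitro.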